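Shortening the side chain of compound 1 to a butyl

The source may hold more compounds than are shown below. What is called first, only, known or untested is meant among the compounds shown, and "the series" means these compounds.

Within the data shown here, compound 1 `CCCCCCCCCCCCCCc1ccccc1C(SCCC(=O)O)SCCC(=O)O` is the stronger of the two compounds measured so far in an assay on membranes from lung (Cavia porcellus) for binding affinity to cysteinyl leukotriene receptor (Homo sapiens) (a higher number here means a weaker inhibitor, a lower number a stronger inhibitor), where compound 1 gives 1250 nM. Its nearest neighbour is compound 2 `CCCCCCCCc1ccccc1C(SCCC(=O)O)SCCC(=O)O`, which in this assay gives 5670 nM; the step of a 4.5-fold higher number from compound 1 to compound 2 (0.66 log units; beyond the scatter) shows that cutting the chain shorter weakened binding. Compound 3 `CCCCc1ccccc1C(SCCC(=O)O)SCCC(=O)O` carries an even shorter chain: the change from compound 1 is hydrogen in place of decyl on a saturated chain carbon, four bonds along the chain from an aromatic carbon. Among the measured compounds shown here, the only step that bears on this is the one from compound 1 to compound 2, where a smaller cut of the same chain already cost a modest amount, so a larger cut is expected to cost more, in the same direction, beyond the scatter. For compound 3 a weaker result is therefore expected, about 25000 nM, with a likely range from 8000 nM to 80000 nM, meaning an expected step of a 20-fold higher number from compound 1 to compound 3 (1.30 log units; beyond the scatter).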

Compound 3, inhibition constant: > 20000 nM
Compound 3: only a limit was reported; the forecaster's own chance of this, stated with the estimate: 20%; the middle value is on the limit's open side.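

In this assay compound 3 gives > 20000 nM as a limit of the assay and not as a number. Even so, the trend now runs through all three compounds with no exception: removing the decyl part of the chain gives an at least 16-fold higher number from compound 1 to compound 3 (1.20 log units; beyond the scatter) and the further cut beyond compound 2 alone gives an at least 3.5-fold higher number from compound 2 to compound 3 (0.54 log units; beyond the scatter). Binding therefore keeps weakening past the first cut, but the full size of this last loss stays unknown, since compound 3 sits at a limit: the limit of > 20000 nM in this assay, at which 1 of the 3 values shown sits.

What the compounds shown leave open is whether a chain longer than the one in compound 1 would bring the number lower still. They also leave open whether a shorter chain carrying a phenyl group or an amine could make up for the lost length.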